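From 2-chlorobenzyl to 2,4-dichlorobenzyl on the shared core

This account rests on a few compounds, and the source may have more. Where it says the series, first, only, none or still open, it means among the compounds named here.

In a functional assay on the whole organism with Rattus norvegicus as the target (on this read-out higher numbers stand for an effect only at larger amounts of compound and lower numbers for an effect already at smaller amounts), compound 1 (`CCN(CCNC(=O)c1cc(Cl)c(N)cc1OC)Cc1ccoc1`) gives 3 mg/kg with its furan-3-yl group, compound 2 (`CCN(CCNC(=O)c1cc(Cl)c(N)cc1OC)Cc1ccccc1OC`) gives 10 mg/kg and compound 3 (`CCN(CCNC(=O)c1cc(Cl)c(N)cc1OC)Cc1ccccc1Cl`) gives 10 mg/kg on the same core. Compound 3 thus stands level with compound 2, and the two share the highest number of the three. Compound 4 (`CCN(CCNC(=O)c1cc(Cl)c(N)cc1OC)Cc1ccc(Cl)cc1Cl`) carries chloro in place of hydrogen on an aromatic carbon, meta to a chloro group and para to a large group (chloro in place of hydrogen on an aromatic carbon), which turns 2-chlorobenzyl into 2,4-dichlorobenzyl. For the measured compounds named here, no measured step adds a group to this ring. Going by the values given here, the closest precedent is chloro in place of methoxy, with no change at the digits printed from compound 2 to compound 3 (within the scatter) and a result within the scatter. The modest steps away from furan-3-yl (a 3.3-fold higher number from compound 1 to compound 2 (0.52 log units; beyond the scatter) and a 3.3-fold higher number from compound 1 to compound 3 (0.52 log units; beyond the scatter)) exchange the whole ring and bear on this change only weakly. In this assay the expected outcome is no change at the digits printed from compound 3 to compound 4 (within the scatter) with no move beyond the scatter in either direction. For compound 4 the estimated value is 10 mg/kg with an expected range from 3 mg/kg to 30 mg/kg on repeated measurement.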

Compound 4, dose for half-maximal effect: 10 mg/kg
Beside the measured number, compound 4's estimate shows no gap at the digits printed; the measured number falls inside the stated range.
By their numbers in this assay, from the lowest: compound 1; then compounds 2, 3 and 4 (each within the scatter of the next).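

Chloro in place of hydrogen is the first step in the series that adds a group to this ring, meta to a chloro group and para to a large group, and in this assay it gives no change at the digits printed from compound 3 to compound 4 (within the scatter). The 2,4-dichlorophenyl group also matches the 2-methoxyphenyl group, with no change at the digits printed from compound 2 to compound 4 (within the scatter), and the gap to the furan-3-yl group remains, with a 3.3-fold higher number from compound 1 to compound 4 (0.52 log units; beyond the scatter), so compounds 2, 3 and 4 all stand apart from compound 1 on the same side. No measurement on hand offers an explanation for this result.

As far as these compounds go, whether this place on the ring tolerates a trifluoromethyl group or an amine as it does chloro remains open. Also open, from the compounds shown here alone, is whether the lower number of compound 1 belongs to furan-3-yl specifically, which an unsubstituted benzyl group or a thiophene ring on the shared core would help to settle.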